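A few compounds are considered here, and "the series" means these few. Any claim that something is new, unique, unknown or untested is made for them only; others in the source may bear on it.

Values measured in a functional assay on THP-1 cells (Homo sapiens), read by colorimetric assay, with a stated time of 1 h; a lower number here means that less compound is needed, a higher number that more compound is needed for the effect:
compound 1 `C=C(C(=O)OCC)C(O)c1ccccc1[N+](=O)[O-]`: 316 nM
compound 2 `C=C(C(=O)OCC)C(OCCC(=O)OCC)c1ccc(Cl)cc1Cl`: 79.4 nM
compound 3 `C/C=C(/C(=O)OCC)C(O)c1ccccc1Cl`: 126 nM

Compound 2, at 79.4 nM, sits at the low end of these numbers, so comparatively little of it is needed for the effect. Compound 3, at 126 nM, lies within the scatter of compound 2, so the two cannot be told apart. Compound 1, at 316 nM, has a higher number than compound 2, and that gap is beyond the scatter.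

The next compound to be tested is compound 4 `C=C(C(=O)OCC)C(OCCC(=O)OCC)c1c(Cl)cccc1Cl`. It has the same atoms as compound 2, joined differently: 2,6-dichlorophenyl in place of 2,4-dichlorophenyl on a saturated chain carbon bound to a double-bonded chain carbon and an oxygen on a saturated carbon. In words, 2,6-dichlorophenyl stands in place of 2,4-dichlorophenyl on a saturated chain carbon bound to a double-bonded chain carbon and an oxygen on a saturated carbon.

Within the data shown here, no two measured compounds differ in only one place, so the data offer no direct precedent for this swap. A change beyond the scatter in this assay is therefore not expected, and no direction can be firmly predicted. The expected size of the change is small, a 1.3-fold higher number from compound 2 to compound 4 (0.10 log units; within the scatter). For compound 4 the estimate is 100 nM, with an expected range of 40 nM to 250 nM.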

Compound 4, half-maximal effective concentration: 126 nM
Compound 4: middle estimate off by 1.3-fold (0.10 log units), on the low side; the measured number falls inside the stated range.
By their numbers in this assay, from the lowest: compounds 2, 3 and 4 (each within the scatter of the next); then compound 1.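

In this assay, putting 2,6-dichlorophenyl in place of 2,4-dichlorophenyl on the saturated chain carbon gives a 1.6-fold higher number from compound 2 to compound 4 (0.20 log units; within the scatter) and so the two compounds cannot be told apart. Among these compounds, this is the first comparison here in which only one place differs, and it shows that this rearrangement of the two chlorines on the ring brings no change that this assay can resolve. Nothing available explains this result.

On these data alone, it remains open whether the number would stay within the scatter if a group other than chlorine, such as methoxy or trifluoromethyl, were carried on this ring. As far as these compounds go, it is also open what a carboxylic acid or an amine would do in place of the ethyl ester at the end of the ether chain.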